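A few compounds are considered here, and "the series" means these few. Any claim that something is new, unique, unknown or untested is made for them only; others in the source may bear on it.

Working notes on the acylated series. Compound 1 `CCCCCCCCCCCCCC(=O)Nc1nnc(S[C@@H]2O[C@H](COC(C)=O)[C@H](OC(C)=O)[C@H](OC(C)=O)[C@H]2OC(C)=O)s1` carries a tetradecanoyl amide on the acetylated sugar; in an ADME assay on CHO-K1 cells (Cricetulus griseus) for cytotoxicity, read by MTT assay, with a stated time of 24 h (on this read-out higher numbers stand for weaker inhibition and lower numbers for stronger inhibition), compound 1 gives 16300 nM. Going by the values given here, compound 3 `CCCCCCCCCCCCCCCC(=O)Nc1nnc(S[C@@H]2O[C@H](COC(C)=O)[C@H](OC(C)=O)[C@H](OC(C)=O)[C@H]2OC(C)=O)s1` lengthens the chain, and in this assay compound 3 gives 90400 nM; the step of a 5.5-fold higher number from compound 1 to compound 3 (0.74 log units; beyond the scatter) is the only single-point comparison measured so far, and it runs toward weaker inhibition as the chain grows. Compound 2 `CCCCCCCCCCCCCCCCCC(=O)Nc1nnc(S[C@@H]2O[C@H](CO)[C@H](O)[C@H](O)[C@H]2O)s1`, with the longest chain and the free sugar, is reported in this assay as "not active" (no number reported), so no number places it against compounds 1 and 3.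

Compound 4 `CCCCCCCCCC(=O)Nc1nnc(S[C@@H]2O[C@H](CO)[C@H](O)[C@H](O)[C@H]2O)s1` is the next member, differing from compound 2 by hydrogen in place of octyl on a saturated chain carbon, nine bonds along the chain from a carbonyl carbon. Among the compounds with values here, no measured step touches the free-sugar pair directly; the only guide is the acetylated step from compound 1 to compound 3, which moved in the direction of weaker inhibition with a longer chain, so the shortening here is expected to move this assay toward stronger inhibition, though whether a number appears at all is uncertain given compound 2. For compound 4 the expected value in this assay is 30000 nM, with a likely range from 5000 nM to 150000 nM.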

Compound 4, half-maximal inhibitory concentration: "not active" (no number reported)
The entry for compound 4 holds no number, and the estimate cannot be compared.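

Compound 2 and compound 4 are both reported as "not active" in this assay, without a number, so no step can be read between them. No evidence bears on this result. As far as these compounds go, how chain length affects the free-sugar compounds remains open.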